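Dimethylamino for pyrrolidin-1-yl on the shared core

A few compounds are considered here, and "the series" means these few. Any claim that something is new, unique, unknown or untested is made for them only; others in the source may bear on it.

Among the compounds with values here, the series so far has three numbers in an ADME assay on L6 cells (Rattus norvegicus) for cytotoxicity, read by resazurin assay, with a stated time of 72 h (on this read-out higher numbers stand for weaker inhibition and lower numbers for stronger inhibition), to work with. Compound 1 (`CN(C)C12CC(OC(=O)CN3CCCC3)C(C(c3ccccc3)C1)C(c1ccccc1)C2`) gives 32700 nM in this read-out. Compound 2 (`CN1CCN(CC(=O)OC2CC3(N(C)C)CC(c4ccccc4)C2C(c2ccccc2)C3)CC1`) gives 39900 nM here. Compound 3 (`CN1CCN(CC(=O)NC2CC3(N4CCCC4)CC(c4ccccc4)C2C(c2ccccc2)C3)CC1`) gives 50200 nM and lies within the scatter of both others, so the three form one level group.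

The next compound, compound 4 (`CN1CCN(CC(=O)NC2CC3(N(C)C)CC(c4ccccc4)C2C(c2ccccc2)C3)CC1`), has dimethylamino in place of pyrrolidin-1-yl on a saturated ring carbon and is otherwise the same as compound 3.

Within the data shown here, the only measured step is a 1.2-fold higher number from compound 1 to compound 2 (0.09 log units; within the scatter) for 4-methylpiperazin-1-yl in place of pyrrolidin-1-yl on a saturated chain carbon bound to a carbonyl carbon. Among the measured compounds shown here, it lies within the scatter but sits at another place, so no measured step tests this exchange directly. Compound 1 at 32700 nM and compound 2 at 39900 nM already carry dimethylamino and stay within the scatter of compound 3 at 50200 nM as a measured guide.

No step beyond the scatter is expected in this assay for this exchange. The estimated size is a 1.1-fold lower number from compound 3 to compound 4 (0.05 log units; within the scatter) and no more than that is expected. Compound 4 is expected at 45000 nM with an estimated range of 25000 nM to 80000 nM as its span.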

Compound 4, half-maximal inhibitory concentration: 66200 nM
Compound 4: the middle estimate sits 1.5-fold (0.17 log units) below what was measured; measured number inside the range.
By their numbers in this assay, from the lowest: compounds 1, 2, 3 and 4 (each within the scatter of the next, the first and the last beyond it).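

Dimethylamino in place of pyrrolidin-1-yl on the saturated ring carbon now has a direct reading in this assay (a 1.3-fold higher number from compound 3 to compound 4 (0.12 log units; within the scatter)), so this exchange leaves the level of the series unchanged, and the linker exchange on the shared core, (((4-methylpiperazin-1-yl)methyl)carbonyl)amino in place of (((4-methylpiperazin-1-yl)methyl)carbonyl)oxy, also stays inside the scatter (a 1.7-fold higher number from compound 2 to compound 4 (0.22 log units; within the scatter)). Within the data shown here, the series' first separation beyond the scatter appears only when the linker and the chain amine differ together, and it is modest (a 2.0-fold higher number from compound 1 to compound 4 (0.31 log units; beyond the scatter)); with dimethylamino fixed, this is the only pair of the four compounds that separates at all, and the two single changes that connect it through compound 2 are each within the scatter. No measured data on the compounds themselves are at hand to account for this small separation.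

As far as these compounds go, whether the flat level holds for other groups on the saturated ring carbon stays open, for example a primary amino group or piperidin-1-yl in place of dimethylamino. Also open, from the compounds shown here alone, is how the amide linker behaves with morpholin-4-yl on the chain, or with a longer chain between the carbonyl and the ring amine.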